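The source may hold more compounds than are shown below. What is called first, only, known or untested is meant among the compounds shown, and "the series" means these compounds.

Among the measured compounds shown here, compound 3 `CC(C(=O)NCc1ccc(C(F)(F)Cl)nc1OCc1cccnc1)c1ccc(NS(C)(=O)=O)c(F)c1` gives 14.6 nM in an assay on CHO cells for antagonist activity at transient receptor potential cation channel subfamily V member 1 (Homo sapiens), read by FLIPR (a higher number here means a weaker inhibitor, a lower number a stronger inhibitor), the highest of the three numbers measured so far; compound 2 `CC(C(=O)NCc1ccc(C(F)(F)Cl)nc1OCc1ccccc1)c1ccc(NS(C)(=O)=O)c(F)c1` gives 0.9 nM and compound 1 `CC(C(=O)NCc1ccc(C(F)(F)Cl)nc1N1CCCCCC1)c1ccc(NS(C)(=O)=O)c(F)c1` gives 0.5 nM in this assay. The step of a 1.8-fold higher number from compound 1 to compound 2 (0.26 log units; within the scatter) lies within the scatter, whereas a 29-fold higher number from compound 1 to compound 3 (1.47 log units; beyond the scatter) and a 16-fold higher number from compound 2 to compound 3 (1.21 log units; beyond the scatter) are both large. Compound 4 `CC(C(=O)NCc1ccc(C(F)(F)Cl)nc1SC1CCCCC1)c1ccc(NS(C)(=O)=O)c(F)c1` differs from compound 3 in one place: cyclohexylsulfanyl in place of (pyridin-3-yl)methoxy on an aromatic carbon. For the measured compounds named here, no measured step contains cyclohexylsulfanyl, so the expectation rests on the two large steps that lead into compound 3: the group that leaves is the very group whose entry raised the number sharply in a 16-fold higher number from compound 2 to compound 3 (1.21 log units; beyond the scatter), and the group that enters is a six-membered ring of carbon only, as are the groups in compound 1 and compound 2. A large downward step is therefore expected, a 9.7-fold lower number from compound 3 to compound 4 (0.99 log units; beyond the scatter), bringing the number back toward those of compound 1 and compound 2. The estimated value for compound 4 in this assay is 1.5 nM, within a range from 0.4 nM to 6 nM.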

Compound 4, inhibition constant: 3 nM
Compound 4: the middle estimate sits 2.0-fold (0.30 log units) below what was measured; low and high end bracket the measured number.
By their numbers in this assay, from the lowest: compounds 1 and 2 (each within the scatter of the next); then compound 4; then compound 3.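

At this aromatic carbon next to the ring nitrogen, cyclohexylsulfanyl gives a lower number than (pyridin-3-yl)methoxy in this assay (a 4.9-fold lower number from compound 3 to compound 4 (0.69 log units; beyond the scatter)). The number still stays above those of the two other compounds, whether cyclohexylsulfanyl replaces benzyloxy (a 3.3-fold higher number from compound 2 to compound 4 (0.52 log units; beyond the scatter)) or azepan-1-yl (a 6.0-fold higher number from compound 1 to compound 4 (0.78 log units; beyond the scatter)). A sulfur-linked, all-carbon six-membered ring is therefore accepted at this position, but unlike the benzyloxy and azepan-1-yl groups, which lie within the scatter of each other, it costs a modest step.

Because cyclohexylsulfanyl differs from benzyloxy in both its linking atom and its ring, the compounds shown leave open which of the two sets the step, a question that a cyclohexyloxy or a phenylsulfanyl group at this place would address. Nothing available here explains any of these differences.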